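A methoxy in place of chloro on the shared core

The source may hold more compounds than are shown below. What is called first, only, known or untested is meant among the compounds shown, and "the series" means these compounds.

Compound 1 (`COc1cc(CNC(=O)Nc2ccc([N+](=O)[O-])cc2)ccc1O`) gives 98700 nM as measured.
Compound 2 (`COc1cc(CNC(=O)Nc2ccc(Cl)cc2)ccc1O`) gives 90500 nM as measured.

Within the data shown here, in a functional assay on SK-MEL-25 cells (Homo sapiens) for cytotoxicity, read by MTT assay, with a stated time of 24 h (a higher number here means a weaker inhibitor, a lower number a stronger inhibitor), compound 2 cannot be told apart from compound 1, the only other compound measured so far (a 1.1-fold lower number from compound 1 to compound 2 (0.04 log units; within the scatter)). Compound 3 (`COc1ccc(NC(=O)NCc2ccc(O)c(OC)c2)cc1`) has not yet been measured. It carries methoxy in place of chloro on an aromatic carbon, para to a large group. Among the measured compounds shown here, only one measured step bears on this change. It falls on the same aromatic carbon, where chloro in place of nitro gave a step within the scatter (a 1.1-fold lower number from compound 1 to compound 2 (0.04 log units; within the scatter)). A single step is slim evidence, but it offers no reason to expect a shift beyond the scatter in this assay and points to no direction. The expected step is a 1.0-fold higher number from compound 2 to compound 3 (0.02 log units; within the scatter) and so no larger than the scatter. Compound 3 is estimated at 95000 nM with an expected range from 50000 nM to 170000 nM in this measurement.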

Compound 3, half-maximal inhibitory concentration: 91800 nM
Compound 3: middle estimate off by 1.0-fold (0.01 log units), on the high side; the range from low to high includes it.
By their numbers in this assay, from the lowest: compounds 2, 3 and 1 (each within the scatter of the next).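

In this assay, methoxy now joins chloro and nitro at this aromatic carbon, para to a large group, and neither new step leaves the scatter (a 1.0-fold higher number from compound 2 to compound 3 (0.01 log units; within the scatter); a 1.1-fold lower number from compound 1 to compound 3 (0.03 log units; within the scatter)). Among these compounds, the earlier compounds offered only the single swap of chloro for nitro, whereas these three groups now form a set in which no pair can be told apart at this position. Methoxy brings a hydrogen-bond acceptor that chloro lacks, yet this change gives no measurable separation, and no evidence shown offers a reason for that result. As far as these compounds go, whether an amine, a carboxylic acid or a longer chain at this carbon would give a step beyond the scatter stays open. So does whether a change elsewhere on the shared core would do so.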